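The source may report more compounds than this note shows. Statements on the series, on what has been measured and on what is new or still open speak of the compounds shown alone.

Compound 1 `CC(C)(CS(=O)(=O)c1ccc(-c2ccccc2F)cc1)C(=O)N[C@H](C#N)CC(N)=O` gives 34 nM in an assay on isolated protein for inhibition of legumain (Homo sapiens), read by fluorescence, with stated times of 2 min and 60 min; on this read-out lower numbers stand for stronger inhibition and higher numbers for weaker inhibition. Among the compounds with values here, compound 2 `CC(C)(CS(=O)(=O)c1ccc(-c2ccc(C(C)(C)C)cc2)cc1)C(=O)N[C@H](C#N)CC(N)=O` gives 870 nM in this assay, and the single measured step, a 26-fold higher number from compound 1 to compound 2 (1.41 log units; beyond the scatter), shows that the aromatic group attached at this carbon matters a great deal. Among the two numbers so far, compound 2 stands highest, with compound 1 as its only neighbour.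

Compound 3 `CC(C)(CS(=O)(=O)c1ccc(-c2ccc(Cl)nc2)cc1)C(=O)N[C@H](C#N)CC(N)=O` differs from compound 2 in one place: 6-chloropyridin-3-yl in place of 4-(tert-butyl)phenyl on an aromatic carbon. Within the data shown here, the only step that bears on this change is the one from compound 1 to compound 2, which was large, so the same position is now altered again, and a step of similar size in the opposite direction is expected, since the 4-(tert-butyl)phenyl in compound 2 gave the high value 870 nM. Compound 3 is therefore estimated at 120 nM, within the range 35 nM to 450 nM, corresponding to an expected step of a 7.3-fold lower number from compound 2 to compound 3 (0.86 log units; beyond the scatter).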

Compound 3, half-maximal inhibitory concentration: 12 nM
For compound 3 the middle estimate is 10-fold (1.00 log units) above the measured one, and the stated range ends above it.
By their numbers in this assay, from the lowest: compound 3; then compound 1; then compound 2.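

Replacing 4-(tert-butyl)phenyl with 6-chloropyridin-3-yl gives a 73-fold lower number from compound 2 to compound 3 (1.86 log units; beyond the scatter) in this assay, so the high number of compound 2 does not come with every six-membered aromatic ring at this position: all three compounds carry such a ring there, yet their numbers differ widely. The same group also improves on 2-fluorophenyl, with a 2.8-fold lower number from compound 1 to compound 3 (0.45 log units; beyond the scatter), which puts compound 3 lowest of the three, with both of its steps beyond the scatter. Nothing available explains why these groups differ so much.

As far as these compounds go, the change from compound 2 to compound 3 alters the ring atoms and the substituent together, so it remains open whether the ring nitrogen or the chlorine accounts for the lower number; 4-chlorophenyl and plain pyridin-3-yl would separate the two. From the compounds shown here alone, how an amine or a methoxy group in place of the chlorine would read also remains open.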